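The compounds below may be only part of what the source reports. "The series", "measured", "known", "first", "only" and "open" are said of these compounds alone.

Measured in a functional assay on NALM-6 cells (Homo sapiens) for cytotoxicity, with a stated time of 72 h; a lower number here means that less compound is needed, a higher number that more compound is needed for the effect:
Compound 1 `C=C[C@@](C)(/C=C/c1ccc(O)cc1)CCC=O`: > 43400 nM
Compound 2 `C=C[C@@](C)(/C=C/c1ccc(O)cc1)CC/C=C/C(=O)OCc1ccccc1`: > 43400 nM

Neither entry is a true number. Compound 1 gives > 43400 nM, which is a limit of the assay. Compound 2 gives > 43400 nM, which is also a limit. Compound 1 therefore stands at the limit of > 43400 nM in this assay, at which 2 of the 2 values shown sit, and no effect has yet been put to a number in this series.

Compound 3 `C=C[C@@](C)(/C=C/c1ccc(O)cc1)CC/C=C(\C)C=O` keeps the core of compound 1 but changes the end of its chain: 2-formylprop-1-en-1-yl in place of formyl on a saturated chain carbon, three bonds along the chain from two double-bonded chain carbons. In words, 2-formylprop-1-en-1-yl takes the place of formyl on a saturated chain carbon, three bonds along the chain from two double-bonded chain carbons.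

Within the data shown here, with only limits so far, no measured step is available to size this change. A modest move towards lower numbers in this assay is expected, though compound 3 may well remain at the limit. The estimate means an at least 1.4-fold lower number from compound 1 to compound 3 (0.16 log units; that floor lies within the scatter), an expected step that is only loosely defined. For compound 3 the estimated value is 30000 nM, with an expected range from 10000 nM to 60000 nM.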

Compound 3, half-maximal effective concentration: 12600 nM
Compound 3: the middle estimate sits 2.4-fold (0.38 log units) above what was measured; the range from low to high includes it.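

In this assay, among these compounds, compound 3 gives the first true number of this series, 12600 nM, which shows that a change at the end of the chain can bring a measurable effect on these cells. Putting 2-formylprop-1-en-1-yl in place of formyl, on a saturated chain carbon, three bonds along the chain from two double-bonded chain carbons, gives an at least 3.4-fold lower number from compound 1 to compound 3 (0.53 log units; beyond the scatter). The true size of this step remains unknown, because its starting point is a limit of the assay and not a number: the limit of > 43400 nM in this assay, at which 2 of the 3 values shown sit.

Compound 2, with a different and longer chain end, gives > 43400 nM, which is also a limit, so a longer chain end does not by itself bring a measurable effect in the compounds shown. Still open, on these data alone, is which part of 2-formylprop-1-en-1-yl matters, whether the double bond, the methyl branch or the formyl group, and what an amine or a carboxylic acid at the same chain end would give.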